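The source may hold more compounds than are shown below. What is called first, only, known or untested is meant among the compounds shown, and "the series" means these compounds.

Compound 1 `O=c1[nH]c(=O)n([C@H]2C[C@H](O)[C@@H](CO)O2)cc1/C=C/I`: 63900 nM
Compound 2 `CCOc1ncnc2c1ncn2C[C@@H]1C[C@H](CO)c2ccccc21`: > 200000 nM
Compound 3 `O=C1O/C(=C\Cn2ccc(=O)[nH]c2=O)C(Cc2ccccc2)=C1O`: > 200000 nM

Three compounds were tested in an ADME assay on L1210/0 cells (Mus musculus) for cytotoxicity, with a stated time of 48 h; on this read-out lower numbers stand for stronger inhibition and higher numbers for weaker inhibition. Compound 1 is the only one of the three to give a number in this assay, reading 63900 nM. For compound 2 this assay reports only a limit, > 200000 nM. For compound 3 the outcome is likewise a limit, > 200000 nM. Two of the three readings therefore sit at the limit of > 200000 nM in this assay, at which 2 of the 3 values shown sit, and compound 1 stands as the sole measured point, beneath that limit.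

Compound 4 `CCCc1cn([C@H]2C[C@H](O)[C@@H](CO)O2)c(=O)[nH]c1=O` has not yet been measured in this assay. It differs from compound 1 in a single place: propyl in place of 2-iodoethenyl on an aromatic carbon. For the measured compounds named here, no step between two measured compounds is available to gauge how such a change shifts this assay, and compounds 2 and 3 share no common scaffold with compound 1 from which a step could be drawn. Because compound 1 reads 63900 nM, weak cytotoxicity is expected for compound 4 as well. A modest rise in the reading, at the edge of the scatter, is expected, a 1.7-fold higher number from compound 1 to compound 4 (0.24 log units; within the scatter). Compound 4 is estimated at 110000 nM, within a range from 30000 nM to 300000 nM.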

Compound 4, half-maximal inhibitory concentration: > 200000 nM
Compound 4 ended at the assay's limit; the forecaster's own chance of this, stated with the estimate: 40%; middle value at least 1.8-fold (0.25 log units) from the limit.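

In this assay, for the compounds shown here, this is the first step between two compounds that differ in one place, and it reads an at least 3.1-fold higher number from compound 1 to compound 4 (0.49 log units; beyond the scatter). The aromatic carbon bearing this group is therefore sensitive to what sits on it, even though 2-iodoethenyl and propyl both count 3 heavy atoms and neither brings a ring, a hydrogen-bond donor or a hydrogen-bond acceptor: the change removes the iodine and the double bond, and the measurable reading of the shared core goes with them. Compound 4 gives only a limit, so the true size of the step stays unknown, and compound 1 remains the only compound with a number: the limit of > 200000 nM in this assay, at which 3 of the 4 values shown sit.

The compounds shown leave open whether the iodine, the double bond or both account for the difference, and a 2-bromoethenyl group or a plain ethenyl group at this place would begin to separate them. They also leave open whether a longer chain or an amine here would read beneath the limit and so give a step of measured size.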